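A few compounds are considered here, and "the series" means these few. Any claim that something is new, unique, unknown or untested is made for them only; others in the source may bear on it.

Measured compounds:
Compound 1 `COc1cc2c(NCc3ccc(C(=O)NO)cc3)cc(-c3ccc(C)o3)nc2cc1OCCCN1CCCC1` in an assay on isolated protein for inhibition of protein deacetylase HDAC6 (Homo sapiens), read by fluorescence, with a stated time of 30 min (on this read-out higher numbers stand for weaker inhibition and lower numbers for stronger inhibition), gives 11 nM.
Compound 2 `COc1cc2c(NCC3CCN(Cc4ccc(C(=O)NO)cc4)CC3)cc(-c3ccc(C)o3)nc2cc1OCCCN1CCCC1` gives 53 nM.
Compound 3 `COc1cc2nc(-c3ccc(C)o3)cc(NCc3ccc(C(=O)NO)cc3)c2cc1OC` gives 22 nM.

Compound 3 stands second highest of the three numbers. Its nearest neighbour is compound 1, with a 2.0-fold higher number from compound 1 to compound 3 (0.30 log units; within the scatter); compound 2 sits furthest away and its number is higher than that of compound 3.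

Compound 4 `COc1cc2nc(-c3ccc(C)o3)cc(NCc3ccc(C(=O)NO)cn3)c2cc1OC` differs from compound 3 by 5-(hydroxycarbamoyl)pyridin-2-yl in place of 4-(hydroxycarbamoyl)phenyl on a saturated chain carbon bound to a nitrogen on an aromatic ring. Within the data shown here, the only measured step, that from compound 1 to compound 3, changes a different part of the molecule, and compound 2 differs from compound 1 elsewhere again, so no measured step bears on this exchange. For this assay the expected step is therefore none beyond the scatter, with a wide range on either side. Compound 4 is expected to give about 30 nM, between 10 nM and 90 nM, corresponding to a 1.4-fold higher number from compound 3 to compound 4 (0.13 log units; within the scatter).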

Compound 4, half-maximal inhibitory concentration: 204 nM
The estimate for compound 4 lay 6.8-fold (0.83 log units) below the measured number; the whole stated range lies below it.
By their numbers in this assay, from the lowest: compounds 1 and 3 (each within the scatter of the next); then compound 2; then compound 4.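

Swapping the aromatic ring on the saturated chain carbon bound to a nitrogen on an aromatic ring proves costly in this assay: 5-(hydroxycarbamoyl)pyridin-2-yl in place of 4-(hydroxycarbamoyl)phenyl gives a 9.3-fold higher number from compound 3 to compound 4 (0.97 log units; beyond the scatter). The heavy-atom count stays the same, so the exchange amounts to one ring carbon replaced by nitrogen and one added hydrogen-bond acceptor. Nothing available explains the size of this step.

The compounds shown leave open whether the step recurs on the core of compound 1. They also leave open how a pyrimidine ring would fare in this place.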